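This account rests on a few compounds, and the source may have more. Where it says the series, first, only, none or still open, it means among the compounds named here.

Compound 3 `C/C(=N\NC(=O)c1ccccc1)c1cnccn1` gives 7040 nM in an ADME assay on MRC5 cells (Homo sapiens) for antiproliferative activity, read by MTT assay (on this read-out higher numbers stand for weaker inhibition and lower numbers for stronger inhibition), and stands at the higher of the two numbers in hand. Its nearest neighbour is compound 1 `C/C(=N\NC(=O)c1cccs1)c1cnccn1`, which gives 5540 nM; the step of a 1.3-fold higher number from compound 1 to compound 3 (0.10 log units; within the scatter) is within the scatter, so the two are not told apart. Compound 2 `C/C(=N\NC(=O)c1ccc(O)cc1)c1cnccn1` gives only a limit of the assay, > 80000 nM. For the measured compounds named here, from that limit, the step of an at least 11-fold lower number from compound 2 to compound 3 (1.05 log units; beyond the scatter) is the one large step.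

Compound 4 `C/C(=N\NC(=O)c1ccc(N)cc1)c1cnccn1` carries amino in place of hydrogen on an aromatic carbon. The change reverses the direction of the step from compound 2, because an at least 11-fold lower number from compound 2 to compound 3 (1.05 log units; beyond the scatter) shows that a hydrogen-bond donor at that aromatic carbon went with a much higher number, and amino, like hydroxy, brings a donor and an acceptor. A step in this assay well beyond the scatter towards a higher number is therefore expected, a 5.0-fold higher number from compound 3 to compound 4 (0.70 log units; beyond the scatter), with a fair chance of a limit, as in the limit of > 80000 nM in this assay, at which 1 of the 3 values shown sits. Compound 4 is estimated at 35000 nM, within 10000 nM to 80000 nM.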

Compound 4, half-maximal inhibitory concentration: > 80000 nM
Compound 4 gave a limit, no number; the forecaster's own chance of this, stated with the estimate: 35%; middle value at least 2.2-fold (0.35 log units) away from the limit.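

In this assay, amino in place of hydrogen gives an at least 11-fold higher number from compound 3 to compound 4 (1.05 log units; beyond the scatter), so the large move at this aromatic carbon, para to a large group, no longer rests on hydroxy alone. Hydroxy in compound 2 and amino in compound 4 both end at a limit of the assay, so the step between them cannot be read and the two groups cannot be ranked. Both compounds with a group at this carbon therefore share the top of the range, and the read-out gives no size for either: the limit of > 80000 nM in this assay, at which 2 of the 4 values shown sit.

Going by these compounds, whether methoxy, fluoro or a carboxylic acid at this aromatic carbon would stay near compound 3 or also reach the limit remains open. Also open, on these data alone, is whether amino would act in the same way on the thiophen-2-yl ring of compound 1.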